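Methyl on the pendant phenyl: a small step, twice

The compounds below may be only part of what the source reports. "The series", "measured", "known", "first", "only" and "open" are said of these compounds alone.

Compound 1 `O=C(Nc1cnn(-c2ccccc2)c1)c1cccc(NS(=O)(=O)c2ccc(Cl)cc2)c1` and compound 2 `Cc1ccc(-n2cc(NC(=O)c3cccc(NS(=O)(=O)c4ccc(Cl)cc4)c3)cn2)cc1` share one core, and compound 3 `O=C(Nc1cnn(-c2ccccc2)c1)c1ccc(NS(=O)(=O)c2ccccc2)cc1` carries a second core; the difference between the two cores is not broken down here. In a functional assay on HeLa cells (Homo sapiens) for inhibition, read by MTT assay, with a stated time of 48 h (a higher number here means a weaker inhibitor, a lower number a stronger inhibitor), compound 1 gives 5410 nM, while compound 2 gives 4570 nM, and compound 3 gives 37100 nM. Among the measured compounds shown here, the only change from compound 1 to compound 2 is methyl in place of hydrogen on an aromatic carbon, and it made a 1.2-fold lower number from compound 1 to compound 2 (0.07 log units; within the scatter). For the measured compounds named here, compound 4 `Cc1ccc(-n2cc(NC(=O)c3ccc(NS(=O)(=O)c4ccccc4)cc3)cn2)cc1` has not yet been measured in this assay; it differs from compound 3 by methyl in place of hydrogen on an aromatic carbon, the same change as the one from compound 1 to compound 2, since the surroundings of the place read the same in both cases. Because that earlier change gave a 1.2-fold lower number from compound 1 to compound 2 (0.07 log units; within the scatter), she expects the step from compound 3 to compound 4 to be a 1.2-fold lower number from compound 3 to compound 4 (0.06 log units; within the scatter), a change that would stay within the scatter. Her estimate for compound 4 in this assay is therefore 32000 nM, with a likely range from 15000 nM to 70000 nM.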

Compound 4, half-maximal inhibitory concentration: 27900 nM
Compound 4: the middle estimate sits 1.1-fold (0.06 log units) above what was measured; the range from low to high includes it.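

In this assay, the methyl on the second core gave a 1.3-fold lower number from compound 3 to compound 4 (0.12 log units; within the scatter), so phenyl to 4-methylphenyl again made a step that cannot be told apart from repeat measurement. Set beside the step on the first core, the two agree: the same change on two cores in this assay, a 1.2-fold lower number (0.07 log units; within the scatter) from compound 1 to compound 2 and a 1.3-fold lower number (0.12 log units; within the scatter) from compound 3 to compound 4, 1.1-fold (0.05 log units) apart, within the scatter of two such steps This shows that, across these two cores, the change carried over as a step within the scatter, which makes it a poor test of transfer: two small steps agree easily, and neither shows that the methyl does anything to the number in this assay, or that the same would hold on a third core.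

The compounds shown leave open whether a larger step could be found at that place with another group, such as an ethyl chain, a methoxy group, an amine or a carboxylic acid, and whether such a step would also carry from one core to the other. They also leave open which part of the difference between the two cores matters, since no pair shown changes those parts one at a time.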